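A few compounds are considered here, and "the series" means these few. Any claim that something is new, unique, unknown or untested is made for them only; others in the source may bear on it.

Measured so far:
Compound 1, `O=C(CSc1nc(Nc2ccccc2)c2ccccc2n1)Nc1ccc(Cl)c(Cl)c1`: 14500 nM in a functional assay on MDA-MB-231 cells (Homo sapiens) for inhibition, read by MTT assay, with a stated time of 72 h; a higher number here means a weaker inhibitor, a lower number a stronger inhibitor
Compound 2, `C=CC(=O)Nc1cccc(NC(=O)CSc2nc(Nc3cccc(F)c3)c3ccccc3n2)c1`: 8160 nM in this assay

Compound 2 gives the lowest of the two numbers, and compound 1 sits only a little higher, a gap that lies within the usual scatter of such measurements, so neither compound can be called the stronger inhibitor on these data. Compound 3, `C=CC(=O)Nc1cccc(NC(=O)CSc2nc(Nc3ccc(Cl)c(Cl)c3)c3ccccc3n2)c1`, keeps the rest of compound 2 and changes a single part: 3,4-dichlorophenyl in place of 3-fluorophenyl on a nitrogen on an aromatic ring. Going by the values given here, no pair of measured compounds differs in this place alone, so no measured step is available for this change; the two known values show only that compound 1, which also carries a 3,4-dichlorophenyl on a nitrogen on an aromatic ring but differs elsewhere as well, gives 14500 nM. For compound 3 the step of a 1.2-fold higher number from compound 2 to compound 3 (0.07 log units; within the scatter) in this assay is expected to stay within the scatter, with no clear direction. Compound 3 is therefore estimated at 9500 nM, within a range from 3500 nM to 26000 nM.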

Compound 3, half-maximal inhibitory concentration: 17700 nM
Compound 3: the middle estimate sits 1.9-fold (0.27 log units) below what was measured; low and high end bracket the measured number.
By their numbers in this assay, from the lowest: compounds 2, 1 and 3 (each within the scatter of the next, the first and the last beyond it).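

In this assay, going by these compounds alone, this is the first single-place change that can be read at the group on the nitrogen: putting 3,4-dichlorophenyl in place of 3-fluorophenyl gives a 2.2-fold higher number from compound 2 to compound 3 (0.34 log units; beyond the scatter). The step is modest but lies beyond the usual scatter, so the group at this position does affect the number, and here the 3-fluorophenyl compound is the stronger inhibitor of the two. This rests on a single pair of compounds, and nothing measured here explains the difference.

The compounds shown leave open whether the step follows from having two chlorines, from their placement, or from losing the fluorine, and a 4-chlorophenyl group on the same nitrogen would help separate these. Also open, on these data alone, is how a phenyl ring carrying a methoxy group or a carboxylic acid would behave at this position.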